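The compounds below may be only part of what the source reports. "The series", "measured", "known", "first", "only" and "open" are said of these compounds alone.

Measured so far in a functional assay on DU-145 cells (Homo sapiens) for inhibition, read by trypan blue exclusion, with a stated time of 96 h; on this read-out lower numbers stand for stronger inhibition of growth and higher numbers for weaker inhibition of growth:

compound 1, `CN(C)c1ccc(/C=C(/SCc2ccc(Cl)cc2Cl)C(=O)c2ccc(Cl)cc2)cc1` — 50000 nM
compound 2, `O=C(/C(=C\c1ccc(O)cc1)SCc1ccc(Cl)cc1)c1ccc(Br)cc1` — 10000 nM
compound 3, `Cc1ccsc1/C=C(/SCc1ccc(F)cc1)C(=O)c1ccc(Br)cc1` — 50000 nM

Compound 1 sits at the weak end of the three numbers. Against compound 3 it shows no difference at the digits given, so the two cannot be ordered; against compound 2 the number for compound 1 is higher by a margin that lies beyond the usual scatter. Among the measured compounds shown here, no pair among the three differs in a single place, so no step between measured compounds can be read off, and the three values only bracket the range in which this small set of compounds falls.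

Compound 4, `CN(C)c1ccc(/C=C(/Sc2ccc(Br)cc2)C(=O)c2ccc(Cl)cc2)cc1`, is the next to be run in this assay. It differs from compound 1 in one place: 4-bromophenyl in place of 2,4-dichlorobenzyl on a sulfur.

For the measured compounds named here, no measured step covers this kind of change here, so the expectation for compound 4 rests on compound 1 alone. The change is expected to move the number in this assay by a small amount at most, not beyond the scatter, with a slight lean toward a lower number. Compound 4 is therefore expected at about 40000 nM, between 15000 nM and 100000 nM. The expected step is a 1.3-fold lower number from compound 1 to compound 4 (0.10 log units; within the scatter).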

Compound 4, concentration for 50% growth inhibition: > 100000 nM
Compound 4 gave a limit, no number; the forecaster's own chance of this, stated with the estimate: 30%; middle value at least 2.5-fold (0.39 log units) away from the limit.
By their numbers in this assay, from the lowest: compound 2; then compounds 1 and 3 (each within the scatter of the next). At a limit, above all of these: compound 4.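

In this assay, the sulfur position now has its first readable single change, 4-bromophenyl in place of 2,4-dichlorobenzyl, and it reads as an at least 2.0-fold higher number from compound 1 to compound 4 (0.30 log units; that floor lies within the scatter). From the compounds shown here alone, compound 4 carries a limit and not a number, so the true size of this step stays unknown and its floor does not separate the pair from the scatter: the limit of > 100000 nM in this assay, at which 1 of the 4 values shown sits. With the rest of the core of compound 1 held fixed, this change brought no gain in growth inhibition on this read-out, and any loss cannot be sized.

The change swaps the benzyl for a phenyl and alters the halogens on the ring at once, so the compounds shown cannot say which of the two matters, and a 4-bromobenzyl on the same sulfur would separate them. Also open, going by these compounds, is whether an aminoethyl chain on that sulfur would give a measurable number on this core at all.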